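The source may report more compounds than this note shows. Statements on the series, on what has been measured and on what is new or still open speak of the compounds shown alone.

For the measured compounds named here, compound 2 `O=c1[nH]c(=O)n([C@H]2C[C@H](O)[C@@H](CO)O2)cc1[N+](=O)[O-]` gives 130 nM in an ADME assay on L1210/0 cells (Mus musculus) for cytotoxicity, with a stated time of 48 h (on this read-out lower numbers stand for stronger inhibition and higher numbers for weaker inhibition), the lowest of the two numbers known here. Compound 1 `COC1=C(OCc2ccc([N+](=O)[O-])cc2)C(=O)O/C1=C\Cn1cnc2c(Cl)ncnc21` gives 13600 nM in this assay, a gap beyond the usual scatter. Compound 3 `C=CC#Cc1cn([C@H]2C[C@H](O)[C@@H](CO)O2)c(=O)[nH]c1=O` has not yet been measured in this assay. Against compound 2 its structure shows one change: a group of 4 heavy atoms (4 carbon; no ring) in place of a group of 3 heavy atoms (1 nitrogen, 2 oxygen; no ring), on an aromatic carbon. Going by the values given here, no step of this kind has been measured on the shared core, so the expectation rests on inference alone. The step is expected to be a 150-fold higher number from compound 2 to compound 3 (2.19 log units; beyond the scatter), in the direction of weaker inhibition. Compound 3 is therefore estimated at 20000 nM, within a range from 2000 nM to 200000 nM.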

Compound 3, half-maximal inhibitory concentration: > 200000 nM
Compound 3: a limit, no number; the forecaster's own chance of this, stated with the estimate: 20%; middle value at least 10-fold (1.00 log units) away from the limit.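

For the compounds shown here, compound 2 and compound 1 gave no step on the shared core, so the position itself had not been tested. Replacing the nitro group on this aromatic carbon with the four-carbon group, which has a double bond and a triple bond, gives an at least 1500-fold higher number from compound 2 to compound 3 (3.18 log units; beyond the scatter), so inhibition depends strongly on what sits here. The reading for compound 3 is a limit, not a number: the limit of > 200000 nM in this assay, at which 1 of the 3 values shown sits.

A single step cannot separate the removal of nitro from the entry of the unsaturated chain. From the compounds shown here alone, how an amine, a bromine atom or a saturated ethyl chain on this carbon would read stays open.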